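Biaryl Amide Esters and Cytotoxicity: Testing a Fluoro-Methoxyphenyl Replacement

The source may report more compounds than this note shows. Statements on the series, on what has been measured and on what is new or still open speak of the compounds shown alone.

Compound 1 `CC(C)N(Cc1cccc(OCCCCCC(=O)O)c1)C(=O)c1ccc(-c2c[nH]c3ccccc23)cc1`: > 26000 nM
Compound 2 `CCOC(=O)CCCCCOc1cccc(CN(C(=O)c2ccc(-c3ccc4ccccc4c3)cc2)C(C)C)c1`: > 26000 nM

In an ADME assay on HepG2 cells (Homo sapiens) for cytotoxicity, read by CellTiter-Glo and resazurin assay, with a stated time of 72 h (a higher number here means that more compound is needed for the effect, a lower number that less compound is needed), compound 1 gives > 26000 nM, which is a limit of the assay and not a number. In this assay compound 2 likewise gives > 26000 nM, again a limit rather than a measured value. Compound 2 therefore stands at the limit of > 26000 nM in this assay, at which 2 of the 2 values shown sit, and no numerical reading places it anywhere else. Nothing can be said of an order between compound 1 and compound 2, since both sit at the same limit.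

Compound 3 `CCOC(=O)CCCCCOc1cccc(CN(C(=O)c2ccc(-c3cc(OC)ccc3F)cc2)C(C)C)c1` is the next compound and differs from compound 2 in one place: 2-fluoro-5-methoxyphenyl in place of naphthalen-2-yl on an aromatic carbon. Among the compounds with values here, no step between two measured compounds is available to gauge such a change. Both measured compounds reach the limit in this assay, so no step beyond the scatter is expected from compound 2 to compound 3; the most likely outcome is that compound 3 also returns only a limit. The expected step is a step that the limit leaves unreadable from compound 2 to compound 3. Compound 3 is estimated at 30000 nM, within the range 15000 nM to 60000 nM.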

Compound 3, half-maximal effective concentration: > 26000 nM
Compound 3: only a limit was reported; the forecaster's own chance of this, stated with the estimate: 75%; the middle value does not contradict the limit.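

In this assay compound 3 gives > 26000 nM as a limit and not a number. No step can be read from compound 2 to compound 3, and all the compounds shown sit at one place: the limit of > 26000 nM in this assay, at which 3 of the 3 values shown sit. What the compounds shown leave open is whether 2-fluoro-5-methoxyphenyl in place of naphthalen-2-yl changes the concentration needed for cytotoxicity at all.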